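A few compounds are considered here, and "the series" means these few. Any claim that something is new, unique, unknown or untested is made for them only; others in the source may bear on it.

Measured so far in a functional assay on BaF3 cells (Mus musculus) for antiproliferative activity, read by CCK-8 assay and cell counting, with a stated time of 76 h; on this read-out higher numbers stand for weaker inhibition and lower numbers for stronger inhibition:
- Compound 1 `COc1cc2nccc(Oc3ccc(Nc4nn(C)cc4C(=O)Nc4ccccc4)cc3)c2cc1C(N)=O`: > 10000 nM, a limit and not a number
- Compound 2 `COc1cc2nccc(Oc3ccc(Nc4nn(C)cc4C(=O)NCC4CCCO4)cc3)c2cc1C(N)=O`: > 10000 nM, a limit and not a number
- Compound 3 `COc1cc2nccc(Oc3ccc(Nc4nn(C)cc4C(=O)Nc4ccc(F)cc4)cc3)c2cc1C(N)=O`: 3060 nM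

Of these three, only compound 3 gives a true number, 3060 nM. The other two sit at the limit of > 10000 nM in this assay, at which 2 of the 3 values shown sit.

Compound 4 `COc1cc2nccc(Oc3ccc(Nc4nn(C)cc4C(=O)N4CCCC5CCCCC54)cc3)c2cc1C(N)=O` keeps the shared core but changes the group on a carbonyl carbon: a group of 10 heavy atoms (9 carbon, 1 nitrogen; one six-membered non-aromatic ring of carbon only, one six-membered non-aromatic ring with 1 hetero atom) in place of a group of 8 heavy atoms (6 carbon, 1 nitrogen, 1 fluorine; one six-membered aromatic ring of carbon only), on a carbonyl carbon.

Within the data shown here, two measured steps bear on this change. One is an at least 3.2-fold lower number from compound 2 to compound 3 (0.51 log units; beyond the scatter), where the group on the amide nitrogen changes. The other is an at least 3.2-fold lower number from compound 1 to compound 3 (0.51 log units; beyond the scatter), where fluoro replaces hydrogen on an aromatic carbon. The step that the two limits leave unreadable from compound 1 to compound 2 gives no guidance. Compound 4 loses the 4-fluorophenyl found in compound 3, so the gain seen in those two steps is expected to reverse, giving a higher number and weaker inhibition, and quite possibly another limit.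

The expected change is a 2.9-fold higher number from compound 3 to compound 4 (0.47 log units; beyond the scatter). For compound 4 the estimated value is 9000 nM, with an expected range of 3000 nM to 30000 nM.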

Compound 4, half-maximal inhibitory concentration: 4330 nM
Estimate against measurement, compound 4: 2.1-fold (0.32 log units) above; the measured number falls inside the stated range.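

In this assay, the step of a 1.4-fold higher number from compound 3 to compound 4 (0.15 log units; within the scatter) shows that a measured number on this read-out does not depend on an aromatic ring on this carbonyl carbon: the group in compound 4 has only non-aromatic rings and 0 hydrogen-bond donors, where (4-fluorophenyl)amino has 1. Among these compounds, the group in compound 4 also stands apart from the other two replacements, with an at least 2.3-fold lower number from compound 2 to compound 4 (0.36 log units; beyond the scatter) and an at least 2.3-fold lower number from compound 1 to compound 4 (0.36 log units; beyond the scatter), so the fluoro group of compound 3 is no longer the only change linked to a measured number. As far as these compounds go, each of these two steps starts from a limit of the assay and not a number, so its full size stays unknown.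

The compounds shown leave open whether both rings of the entering group matter, which a simple piperidine amide could test. They also leave open how chloro or methoxy in place of the fluoro in compound 3 would read.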